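A Smaller Sulfur Group on the Shared Core

The source may report more compounds than this note shows. Statements on the series, on what has been measured and on what is new or still open speak of the compounds shown alone.

In a functional assay on cells (Neutrophil, Homo sapiens) for inhibition, read by WST assay, with a stated time of 20 min (a lower number here means a stronger inhibitor, a higher number a weaker inhibitor), compound 2 `CNC1=C(Sc2ccccc2)C(=O)c2ncccc2C1=O` gives only a limit, > 150000 nM. Compound 1 `CNC1=C(SC)C(=O)c2ncccc2C1=O` likewise gives only a limit in this assay, > 200000 nM. Because both values sit at limits, the limit of > 150000 nM in this assay, at which 1 of the 2 values shown sits, and (the limit of > 200000 nM in this assay, at which 1 of the 2 values shown sits), the step that the two limits leave unreadable from compound 1 to compound 2 cannot be read in size or direction. Compound 3 `CNC1=C([S+](C)[O-])C(=O)c2ncccc2C1=O` differs from compound 2 by a group of 3 heavy atoms (1 carbon, 1 oxygen, 1 sulfur; no ring) in place of a group of 7 heavy atoms (6 carbon, 1 sulfur; one six-membered aromatic ring of carbon only), on a double-bonded ring carbon. Within the data shown here, no measured step bears readably on this change, so no shift beyond the scatter is expected. Compound 3 is estimated at 150000 nM, with a range from 30000 nM to 500000 nM, most likely again reported as a limit. That estimate means an expected step of a number no higher from compound 2 to compound 3 (the limit leaves the size open).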

Compound 3, half-maximal inhibitory concentration: > 200000 nM
Compound 3 was reported as a limit; the forecaster's own chance of this, stated with the estimate: 80%; middle value at least 1.3-fold (0.12 log units) away from the limit.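

In this assay, among these compounds, compound 3 also gives only a limit, > 200000 nM and no step among compound 1, compound 2 and compound 3 can be read. As far as these compounds go, how these sulfur groups on the shared core rank stays open.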